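Pyridin-2-yl Replaces Cyclobutyl on the Amide of Compound 1

A few compounds are considered here, and "the series" means these few. Any claim that something is new, unique, unknown or untested is made for them only; others in the source may bear on it.

Compound 1, `COc1cccc(OC)c1C(=O)Nc1c[nH]nc1C(=O)NC1CCC1`: > 50000 nM
Compound 2, `CO[C@H]1CC[C@H](NC(=O)c2n[nH]cc2NC(=O)c2ccc(OC(F)F)cc2)CC1`: 2500 nM
Compound 3, `COc1cc(OC)c(C(=O)Nc2c[nH]nc2C(=O)N[C@H]2CC[C@H](OC)CC2)c(OC)c1`: > 50000 nM

In an ADME assay on MRC5 cells (Homo sapiens) for inhibition, with a stated time of 72 h (a lower number here means that less compound is needed, a higher number that more compound is needed for the effect), compound 1 gives > 50000 nM, which is a limit of the assay rather than a number. Compound 3 likewise returns only a limit, > 50000 nM. Among the measured compounds shown here, compound 2 is the one compound with a numeric value, 2500 nM. Compound 1 therefore sits at the limit of > 50000 nM in this assay, at which 2 of the 3 values shown sit, the edge of what the data show.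

Compound 4, `COc1cccc(OC)c1C(=O)Nc1c[nH]nc1C(=O)Nc1ccccn1`, differs from compound 1 by pyridin-2-yl in place of cyclobutyl on an amide-type nitrogen. For the measured compounds named here, no measured pair carries this change, so its effect remains open. In this assay the step is expected to stay within the scatter, an at least 1.2-fold lower number from compound 1 to compound 4 (0.09 log units; that floor lies within the scatter). Compound 4 is estimated at 40000 nM, within 8000 nM to 50000 nM, and quite possibly again only a limit.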

Compound 4, half-maximal effective concentration: > 50000 nM
Compound 4: a limit, no number; the forecaster's own chance of this, stated with the estimate: 60%; middle value at least 1.2-fold (0.09 log units) away from the limit.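

Among the compounds shown here, compound 1 and compound 4 both end at a limit in this assay, so no step between them can be read: the limit of > 50000 nM in this assay, at which 3 of the 4 values shown sit. On these data alone, whether pyridin-2-yl in place of cyclobutyl on the amide-type nitrogen shifts the value at all stays open.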